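The source may hold more compounds than are shown below. What is called first, only, known or untested is meant among the compounds shown, and "the series" means these compounds.

Compounds measured so far, in a functional assay on PC-3 cells (Homo sapiens) for antiproliferative activity, read by MTT assay, with a stated time of 48 h; on this read-out lower numbers stand for stronger inhibition and higher numbers for weaker inhibition:

Compound 1, `O=C1c2ccccc2C(=O)N1c1nc(-c2ccc(Cl)cc2)cs1` — compound 1 gives 44900 nM.
Compound 2, `Cc1ccc(-c2csc(N3C(=O)c4ccccc4C3=O)n2)cc1` — compound 2 gives 38400 nM.
Compound 3, `COc1ccc(-c2csc(N3C(=O)c4ccccc4C3=O)n2)cc1` — compound 3 gives 42900 nM.

All three share one core and differ only in the group on the pendant six-membered aromatic ring. The numbers sit close together: the step of a 1.2-fold lower number from compound 1 to compound 2 (0.07 log units; within the scatter) and the step of a 1.0-fold lower number from compound 1 to compound 3 (0.02 log units; within the scatter) both stay within the scatter, as does the step of a 1.1-fold higher number from compound 2 to compound 3 (0.05 log units; within the scatter). Compound 3 therefore lies within the scatter of both compound 1 and compound 2, nearest to compound 1 and furthest from compound 2, with neither gap meaning anything.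

Compound 4, `N#Cc1ccc(-c2csc(N3C(=O)c4ccccc4C3=O)n2)cc1`, has not yet been measured. It differs from compound 3 by cyano in place of methoxy on an aromatic carbon. The three measured steps all swap one group at this same position and none of them moved the number beyond the scatter, so the change to compound 4 is expected to behave alike. The step of a 1.0-fold lower number from compound 3 to compound 4 (0.01 log units; within the scatter) is thus estimated to stay within the scatter, in no clear direction. Compound 4 is expected to give about 42000 nM in this assay, in the range from 20000 nM to 90000 nM.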

Compound 4, half-maximal inhibitory concentration: 40300 nM
Beside the measured number, compound 4's estimate is 1.0-fold (0.02 log units) above it; low and high end bracket the measured number.
By their numbers in this assay, from the lowest: compounds 2, 4, 3 and 1 (each within the scatter of the next).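

In this assay, cyano in this place, on an aromatic carbon para to a large group, gives no step beyond the scatter against any of the three earlier groups: methoxy (a 1.1-fold lower number from compound 3 to compound 4 (0.03 log units; within the scatter)), methyl (a 1.0-fold higher number from compound 2 to compound 4 (0.02 log units; within the scatter)) and chloro (a 1.1-fold lower number from compound 1 to compound 4 (0.05 log units; within the scatter)). The earlier compounds had shown this only among chloro, methyl and methoxy, and the first group with a triple bond outside aromatic rings now fits the same picture, so all four compounds lie within the scatter of one another. No evidence is at hand on why the number stays put across these swaps.

The compounds shown leave open whether a different kind of group in this place, such as an amine, a carboxylic acid or a longer chain, would move the number beyond the scatter. They also leave open whether a change elsewhere on the shared core would do so.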